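The source may report more compounds than this note shows. Statements on the series, on what has been measured and on what is new or still open speak of the compounds shown alone.

Measured so far in a functional assay on the whole organism (strain Jcl:SD) for inhibition, with Rattus norvegicus as the target, with stated times of 3 min and 3 h, at a dose of 1 mg/kg by the intravenous route; on this read-out higher numbers stand for more inhibition at the one dose given (going by the name of the read-out) and lower numbers for less inhibition:

compound 1 `CNCc1cc(-c2ccccc2)n(S(=O)(=O)c2ccc(C)cc2)c1` gives 66%
compound 2 `CNCc1cc(-c2ccccc2)n(S(=O)(=O)c2ccccc2)c1` gives 96%
compound 3 `CNCc1cc(-c2cccnc2F)n(S(=O)(=O)c2cccnc2)c1` gives 96%

The one counted step among these is a number 30 percentage points lower from compound 2 to compound 1 (beyond the scatter), the change being (methyl in place of hydrogen on an aromatic carbon). Compound 3 and compound 2 differ in more than one place; the difference between the two cores is not broken down here, and in this assay their values are level at the digits printed, within the usual scatter.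

Compound 4 `CNCc1cn(S(=O)(=O)c2cccnc2)c(-c2cccnc2F)c1C` carries the same kind of change as compound 1, but at a different place: methyl in place of hydrogen on an aromatic carbon. In compound 1 the methyl sits on a six-membered aromatic ring of carbon only, para to a large group; in compound 4 it sits on a five-membered aromatic ring with 1 nitrogen, next to the ring atom that bears a (methylamino)methyl group and next to the ring atom that bears a 2-fluoropyridin-3-yl group. Within the data shown here, whether a methyl placed there acts like the earlier one is uncertain, since only that one step is known. Because compound 2 to compound 1 showed a number 30 percentage points lower from compound 2 to compound 1 (beyond the scatter), a drop is expected, though smaller: the estimated step is a number 16 percentage points lower from compound 3 to compound 4 (beyond the scatter). Compound 4 is therefore expected to give about 80%, between 55% and 98%.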

Compound 4, a percentage reported as inhibition, in the whole organism at one dose (the size of the read-out at that dose, not a potency) in the Rattus norvegicus assay: 93%
Estimate against measurement, compound 4: 13 percentage points below, within the range that was stated.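

On the core of compound 3, putting a methyl in place of hydrogen in the Rattus norvegicus assay gives a number 3 percentage points lower from compound 3 to compound 4 (within the scatter), so the clear loss of inhibition seen with this change on the core of compound 2 does not reappear here, and the two steps differ: the same change on two cores in the Rattus norvegicus assay, a number 30 percentage points lower (beyond the scatter) from compound 2 to compound 1 and a number 3 percentage points lower (within the scatter) from compound 3 to compound 4, 27 percentage points apart, beyond the scatter of two such steps In a physicochemical assay for lipophilicity, read by HPLC, at pH 7.4 (on this read-out lower numbers stand for lower lipophilicity and higher numbers for higher lipophilicity), compound 3 gives -0.85 and compound 4 gives -0.4, which is a number 0.45 log units higher from compound 3 to compound 4 (beyond the scatter), so this methyl does leave a measurable mark even though the inhibition stays level. What this does not show is why the steps differ, since the two methyl groups sit on different rings as well as on different cores, and two steps cannot separate the effect of the place from that of the core.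

On these data alone, it remains open how the same methyl would behave on the core of compound 3 at the place it holds in compound 1. Also open, as far as these compounds go, is whether an ethyl or a methoxy group on the same aromatic carbon of compound 4 would keep the inhibition.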